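A few compounds are considered here, and "the series" means these few. Any claim that something is new, unique, unknown or untested is made for them only; others in the source may bear on it.

Measured so far in an ADME assay on A549 cells (Homo sapiens) for cytotoxicity, read by resazurin assay, with a stated time of 48 h; a lower number here means that less compound is tolerated, a higher number that more compound is tolerated:
- compound 1 `O=C(Nc1ccc(NCc2ccc(Cl)cc2)cc1Cl)c1cc(Cl)ccc1O` gives 59700 nM in this test
- compound 2 `O=C(Nc1ccc(NCc2cccc(C(F)(F)F)c2)cc1Cl)c1cc(Cl)ccc1O` gives 13300 nM in this test
- compound 3 `CN(C)c1ccc(CNc2ccc(NC(=O)c3cc(Cl)ccc3O)c(Cl)c2)cc1` gives 24500 nM in this test

The numbers place compound 3 inside the span of the other two. On one side the data show a 1.8-fold higher number from compound 2 to compound 3 (0.27 log units; within the scatter) and on the other 2.4-fold lower number from compound 1 to compound 3 (0.39 log units; beyond the scatter) for the same comparison set.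

The next compound, compound 4 `O=C(Nc1ccc(NCc2cccc(Br)n2)cc1Cl)c1cc(Cl)ccc1O` in the drawing, keeps the shared core. It changes only the group on a saturated chain carbon bound to a nitrogen on an aromatic ring, and 6-bromopyridin-2-yl in place of 4-(dimethylamino)phenyl on a saturated chain carbon bound to a nitrogen on an aromatic ring sums up that swap, 6-bromopyridin-2-yl in place of 4-(dimethylamino)phenyl.

Three measured steps changed this same group: a 4.5-fold lower number from compound 1 to compound 2 (0.65 log units; beyond the scatter) as the largest, then a 2.4-fold lower number from compound 1 to compound 3 (0.39 log units; beyond the scatter) and a 1.8-fold higher number from compound 2 to compound 3 (0.27 log units; within the scatter) as the smaller ones. All three are modest or within the scatter. For the measured compounds named here, none of the measured compounds carries a pyridine ring or a bromine, so the data favour no direction for this swap. Only a small change is therefore expected in this assay here.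

The estimate means a 1.1-fold higher number from compound 3 to compound 4 (0.03 log units; within the scatter) in expectation, which is no step beyond the scatter. For compound 4 the expected value is 26000 nM with an estimated range from 11000 nM to 60000 nM in this test.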

Compound 4, half-maximal cytotoxic concentration: 92300 nM
Compound 4: the middle estimate sits 3.6-fold (0.55 log units) below what was measured, outside the stated range (above it).
By their numbers in this assay, from the lowest: compounds 2 and 3 (each within the scatter of the next); then compounds 1 and 4 (each within the scatter of the next).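

In this assay, 6-bromopyridin-2-yl on a saturated chain carbon bound to a nitrogen on an aromatic ring gives a 3.8-fold higher number from compound 3 to compound 4 (0.58 log units; beyond the scatter) and a 6.9-fold higher number from compound 2 to compound 4 (0.84 log units; beyond the scatter) as the widest step yet seen for a change of this group. Until now, every swap here had gone from compound 1 to a lower number or stayed within the scatter between compound 2 and compound 3, but this result shows that a ring with a hetero atom and a bromine can stand level with the 4-chlorophenyl group: the comparison gives a 1.5-fold higher number from compound 1 to compound 4 (0.19 log units; within the scatter) and lies within the scatter. So compound 1 and compound 4 form a higher pair, set apart from compound 2 and compound 3 on these four numbers alone, and nothing measured here explains that split.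

The compounds shown leave open whether the ring nitrogen or the bromine accounts for the rise, which a plain pyridin-2-yl or a bromophenyl group at the same place could separate. They also leave open how a pyridine ring carrying a chloro group, a methoxy group or a carboxylic acid instead of the bromine would read in this assay on this same core.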